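Acetylation of the ring amine on two related cores

The compounds below may be only part of what the source reports. "The series", "measured", "known", "first", "only" and "open" are said of these compounds alone.

Measured so far:
compound 1 `Nc1cc(OCc2ccccc2)nc(SCc2ccccc2)n1` gives 49000 nM
compound 2 `CC(=O)Nc1cc(OCc2ccccc2)nc(SCc2ccccc2)n1` gives 42900 nM
compound 3 `Nc1cc(=O)n(Cc2ccccc2)c(SCc2ccccc2)n1` gives 97800 nM

All three were measured in a functional assay on HepG2 cells (Homo sapiens) for antiproliferative activity, read by MTT assay, with a stated time of 72 h; a lower number here means a stronger inhibitor of growth, a higher number a weaker inhibitor of growth. Compound 2 differs from compound 1 by acetyl in place of hydrogen on a nitrogen on an aromatic ring, and the step is a 1.1-fold lower number from compound 1 to compound 2 (0.06 log units; within the scatter). Compound 3 shares its atoms with compound 1 but has them joined differently; the difference between the two cores is not broken down here. In this assay compound 3 gives 97800 nM, and its values against compound 1 and compound 2 are as shown.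

Compound 4 `CC(=O)Nc1cc(=O)n(Cc2ccccc2)c(SCc2ccccc2)n1` is not yet measured. It differs from compound 3 by acetyl in place of hydrogen on a nitrogen on an aromatic ring, the same kind of change as from compound 1 to compound 2, at a place described in the same words. Because the earlier step was a 1.1-fold lower number from compound 1 to compound 2 (0.06 log units; within the scatter), the step from compound 3 to compound 4 is expected to be small as well, about a 1.1-fold lower number from compound 3 to compound 4 (0.04 log units; within the scatter). Compound 4 is therefore estimated at 90000 nM in this assay, with a range from 40000 nM to 200000 nM; this rests on one prior pair only.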

Compound 4, concentration for 50% growth inhibition: 71700 nM
Compound 4: the middle estimate sits 1.3-fold (0.10 log units) above what was measured; the measured number falls inside the stated range.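

On the second core, the change from amino to acetamido comes to a 1.4-fold lower number from compound 3 to compound 4 (0.13 log units; within the scatter). Across the two cores, the change reads alike in this assay: the same change on two cores in this assay, a 1.1-fold lower number (0.06 log units; within the scatter) from compound 1 to compound 2 and a 1.4-fold lower number (0.13 log units; within the scatter) from compound 3 to compound 4, 1.2-fold (0.08 log units) apart, within the scatter of two such steps

Both steps lie within the scatter, so the two pairs show no gain from the acetyl, and they give no rule for any further core. Still open, on these data alone, is whether another group on that nitrogen, such as a longer acyl chain or a methanesulfonyl group, would give a step beyond the scatter on either core. Equally open, as far as these compounds go, is whether the amino to acetamido step stays this small once other parts of the cores are changed, for instance by adding an amine or a carboxylic acid.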